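The source may report more compounds than this note shows. Statements on the series, on what has been measured and on what is new or still open speak of the compounds shown alone.

Among the measured compounds shown here, in an assay on membranes from frontal cortex for displacement of a labelled ligand from Adrenergic receptor alpha-1 (Rattus norvegicus), read by scintillation counting, with a stated time of 45 min (a lower number here means a stronger inhibitor, a higher number a weaker inhibitor), compound 1 `CCC1(CCCCN2CCN(c3ccccc3OC)CC2)C(=O)Nc2ccccc21` gives 27 nM, the lowest of the three numbers measured so far. Compound 2 `CCC1(CCCCN2CCN(c3ccccc3Cl)CC2)C(=O)Nc2ccccc21` gives 64 nM in this assay, and compound 3 `CCC1(CCCCN2CCN(c3cccc(Cl)c3)CC2)C(=O)Nc2cc(F)c(Cl)cc21` gives 117 nM, so compound 1 stands clearly ahead of both, with compound 2 nearest and compound 3 furthest away.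

For the measured compounds named here, the only step between two compounds that differ in a single place is the one from compound 1 to compound 2, where the change is chloro in place of methoxy on an aromatic carbon: a 2.4-fold higher number from compound 1 to compound 2 (0.37 log units; beyond the scatter). Compound 3 also carries a chlorophenyl group on the amine nitrogen in a ring, but it differs from compound 1 in more than one place, so it offers only its own number, not a clean step.

Compound 4 `CCC1(CCCCN2CCN(c3ccc(Cl)cc3)CC2)C(=O)Nc2ccccc21` is not yet measured in this assay. It differs from compound 1 in a single place: 4-chlorophenyl in place of 2-methoxyphenyl on an amine nitrogen in a ring. This again exchanges the methoxy-bearing phenyl group for a chlorine-bearing one, so the step from compound 1 to compound 2 is the closest guide, and a step of similar modest size toward a higher number, beyond the scatter, is expected: a 2.2-fold higher number from compound 1 to compound 4 (0.35 log units; beyond the scatter). Compound 4 is therefore estimated to give 60 nM, within a range from 25 nM to 140 nM.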

Compound 4, inhibition constant: 93 nM
Beside the measured number, compound 4's estimate is 1.6-fold (0.19 log units) below it; the measured number falls inside the stated range.
By their numbers in this assay, from the lowest: compound 1; then compounds 2, 4 and 3 (each within the scatter of the next).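

In this assay, 4-chlorophenyl in place of 2-methoxyphenyl on the amine nitrogen in the ring gives a 3.4-fold higher number from compound 1 to compound 4 (0.54 log units; beyond the scatter) and is beyond the scatter, so a second chlorine-bearing phenyl group also stands apart from the methoxy compound, as the chlorine of compound 2 did. The new comparison is between the two chlorine-bearing groups: 4-chlorophenyl in place of 2-chlorophenyl gives a 1.5-fold higher number from compound 2 to compound 4 (0.16 log units; within the scatter) and shows that, in this one pair, where the chlorine sits on the phenyl group makes no difference that can be told from the scatter. Among compounds 1, 2 and 4, which share the same core, the 2-methoxyphenyl group therefore gives the lowest number, and neither chlorine placement matches it.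

A 4-methoxyphenyl group or a plain phenyl group on the same nitrogen would help to separate the effect of the methoxy group itself from that of its place on the ring, and would show how far either chlorine moves the number from an unsubstituted ring. No measurement at hand speaks to why these numbers differ.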